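From furan-2-yl to 4-chlorophenyl on the shared core

A few compounds are considered here, and "the series" means these few. Any claim that something is new, unique, unknown or untested is made for them only; others in the source may bear on it.

Measured compounds:
compound 1 `O=C(NO)c1ccc(NCc2nc(-c3ccco3)nn2-c2ccccc2)cc1` gives 59.9%
compound 2 `O=C(NO)c1ccc(NCc2nc(-c3cccc(Cl)c3)nn2-c2ccccc2)cc1` gives 61.2%
compound 3 `COc1ccc(-n2nc(-c3ccc(O)cc3)nc2CNc2ccc(C(=O)NO)cc2)cc1` gives 70.3%

In an assay on Sf9 cells for inhibition of protein deacetylase HDAC6 (Homo sapiens), read by fluorescence, with a stated time of 40 min, tested at 100 nM (on this read-out higher numbers stand for more inhibition at the one concentration tested (going by the name of the read-out) and lower numbers for less inhibition), compound 1 has the lowest of the three numbers. Compound 2 is nearest, a number 1.3 percentage points higher from compound 1 to compound 2 (within the scatter), which lies within the scatter, so the two cannot be ordered. Compound 3 stands furthest, its number higher by more than the scatter.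

Compound 4 `O=C(NO)c1ccc(NCc2nc(-c3ccc(Cl)cc3)nn2-c2ccccc2)cc1` differs from compound 1 by 4-chlorophenyl in place of furan-2-yl on an aromatic carbon. For the measured compounds named here, the one measured step that bears on this is the swap of furan-2-yl for 3-chlorophenyl, a number 1.3 percentage points higher from compound 1 to compound 2 (within the scatter), within the scatter. On that basis a step no larger than the scatter is expected, with no clear direction. For compound 4 the estimate is 61%, ranging from 50% to 72%, meaning an expected step of a number 1.1 percentage points higher from compound 1 to compound 4 (within the scatter).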

Compound 4, a percentage reported as inhibition, at one concentration (the size of the read-out at that concentration, not a potency): 67.2%
The estimate for compound 4 lay 6.2 percentage points below the measured number, and the stated range covers the measured number.
By their numbers in this assay, from the lowest: compounds 1, 2, 4 and 3 (each within the scatter of the next, the first and the last beyond it).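

In this assay the change from furan-2-yl to 4-chlorophenyl gives a number 7.3 percentage points higher from compound 1 to compound 4 (within the scatter) and the change from 3-chlorophenyl to 4-chlorophenyl gives a number 6 percentage points higher from compound 2 to compound 4 (within the scatter). At this position on the shared core, then, neither replacing furan-2-yl with a chlorophenyl group nor changing where the chlorine sits gives a step that can be told from the scatter. Nothing available explains these small steps. Open, from the compounds shown here alone, is whether a group of another kind here, such as an amine or a carboxylic acid, would give a step beyond the scatter.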